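Enaminone series: hydroxy for chloro on the anilino ring

The compounds below may be only part of what the source reports. "The series", "measured", "known", "first", "only" and "open" are said of these compounds alone.

Measured so far:
compound 1, `O=C(/C=C\Nc1ccc(O)cc1)c1cn(-c2ccccc2)nc1-c1ccc(F)cc1`, 1500 nM
compound 2, `COc1ccc(-c2nn(-c3ccccc3)cc2C(=O)/C=C\Nc2ccc(Cl)cc2)cc1`, 2970 nM

Of the compounds shown here, two of the shared core have been measured in a functional assay on A549 cells (Homo sapiens) for antiproliferative activity, read by MTT assay, with a stated time of 48 h; a higher number here means a weaker inhibitor, a lower number a stronger inhibitor. Compound 1 gives 1500 nM and compound 2 gives 2970 nM. Compound 2 holds the higher of the two numbers, but its nearest neighbour is compound 1, and the gap between them lies within the usual scatter, so no order between the two can be stated. For the measured compounds named here, compound 1 and compound 2 differ from each other in two places, and no single step between them is available.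

Compound 3, `COc1ccc(-c2nn(-c3ccccc3)cc2C(=O)/C=C\Nc2ccc(O)cc2)cc1`, has not yet been measured. It differs from compound 2 in one place: hydroxy in place of chloro on an aromatic carbon. The same change in that ring is present in compound 1, whose value in this assay is 1500 nM, the other ring carrying a different substituent. On that basis the step from compound 2 to compound 3 is expected to be small, at most toward a slightly lower number, and probably not beyond the scatter: a 1.7-fold lower number from compound 2 to compound 3 (0.22 log units; within the scatter). Compound 3 is therefore estimated at 1800 nM, with a range of 700 nM to 5000 nM.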

Compound 3, half-maximal inhibitory concentration: 2770 nM
The estimate for compound 3 lay 1.5-fold (0.19 log units) below the measured number; the measured number falls inside the stated range.
By their numbers in this assay, from the lowest: compounds 1, 3 and 2 (each within the scatter of the next).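

Hydroxy in place of chloro on an aromatic carbon, para to a large group, can now be read as a single change in this assay (a 1.1-fold lower number from compound 2 to compound 3 (0.03 log units; within the scatter)), so the hydrogen-bond donor and acceptor that hydroxy brings and chloro lacks leave no readable mark on the number at this position. For the compounds shown here, the same compound also gives the first single-change reading at the other substituent, methoxy in place of fluoro on an aromatic carbon (a 1.8-fold higher number from compound 1 to compound 3 (0.27 log units; within the scatter)), and neither change can be told apart from repeat measurement. No supporting data bear on why the numbers sit where they do.

Still open, going by these compounds, is whether this position tolerates every group or only the two seen here: an amine, a carboxylic acid or a longer alkoxy chain in place of hydroxy would need numbers of their own to show whether any step leaves the scatter. The same holds for the site carrying methoxy or fluoro, where a single pair of groups gives no indication of how far the number can move.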